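Dimethylamino for bromo on the shared core

This account rests on a few compounds, and the source may have more. Where it says the series, first, only, none or still open, it means among the compounds named here.

Compound 1 `O=C(N/N=C/c1ccc(Br)cc1)Nc1cccc2ccccc12` is tested in a functional assay on the whole organism (strain Swiss albino) with Mus musculus as the target, in the maximal electroshock model, with a stated time of 0.5 h (on this read-out lower numbers stand for an effect already at smaller amounts and higher numbers for an effect only at larger amounts of compound), where compound 1 gives 300 mg/kg. Compound 3 `C/C(=N\NC(=O)Nc1cccc2ccccc12)c1ccccc1` gives 300 mg/kg in this assay, the same figure at the digits shown, so the two sit together at the high end of the three numbers. Compound 2 `O=C(N/N=C/c1ccc(O)cc1)Nc1cccc2ccccc12` gives 100 mg/kg, the lowest of the set; the step of a 3.0-fold lower number from compound 1 to compound 2 (0.48 log units; beyond the scatter) is the only one within the data and it is modest.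

Compound 4 `CN(C)c1ccc(/C=N/NC(=O)Nc2cccc3ccccc23)cc1` is not yet measured. Its change from compound 1 is dimethylamino in place of bromo on an aromatic carbon. Going by the values given here, the one comparison that bears on it is the replacement of bromo by hydroxy at the same place in compound 2, which moved the number as a 3.0-fold lower number from compound 1 to compound 2 (0.48 log units; beyond the scatter). Among the compounds with values here, a dimethylamino group is not a hydroxy group, so that step is only a loose guide, and no other measured pair touches this position.

Compound 4 is therefore expected to lie between compound 1 and compound 2, estimated at 200 mg/kg with a range of 100 mg/kg to 300 mg/kg, which is expected to mean a step of a 1.5-fold lower number from compound 1 to compound 4 (0.18 log units; within the scatter).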

Compound 4, minimum effective dose: 100 mg/kg
Compound 4: middle estimate off by 2.0-fold (0.30 log units), on the high side; low and high end bracket the measured number.
By their numbers in this assay, from the lowest: compounds 2 and 4 (each within the scatter of the next); then compounds 1 and 3 (each within the scatter of the next).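

In this assay, a second replacement of bromo on this aromatic carbon, para to a large group, also gives a lower number, with a 3.0-fold lower number from compound 1 to compound 4 (0.48 log units; beyond the scatter). The comparison with the hydroxy compound gives no change at the digits printed from compound 2 to compound 4 (within the scatter), so the two replacements read alike here, and the lower number does not require a hydrogen-bond donor in the entering group, as dimethylamino carries 0 hydrogen-bond donors. No measurement at hand explains why either replacement differs from bromo.

As far as these compounds go, only bromo, hydroxy and dimethylamino are compared at this place, so a methoxy group, a primary amine or a carboxylic acid there remains open. Also open, from the compounds shown here alone, is whether a smaller halogen such as chloro or fluoro would read like bromo or like the other two groups.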